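Methoxy for Methyl on the Carbonyl: Cytotoxicity Expectation

The compounds below may be only part of what the source reports. "The series", "measured", "known", "first", "only" and "open" are said of these compounds alone.

Measured so far in a toxicity assay on NIH3T3 cells (Mus musculus) for cytotoxicity, read by resazurin assay; on this read-out higher numbers stand for an effect only at larger amounts of compound and lower numbers for an effect already at smaller amounts:
compound 1 `CC(=O)c1ccc(NCc2cncn2Cc2ccc(-c3ccccc3)cc2)cc1-c1ccccc1` gives > 10000 nM.
compound 2 `COC(=O)c1ccc(NCc2cncn2Cc2ccccc2C)cc1-c1ccccc1` gives 10000 nM.
compound 3 `COC(=O)c1ccc(NCc2cncn2Cc2cccc(F)c2)cc1-c1ccccc1` gives > 1000 nM.

Compound 1 has a reported value that is a limit of the assay, not a number. Compound 2 gives a plain number, 10000 nM. Compound 3 again has a value that is a limit of the assay. Between these three only one pair differs in a single place, and that step, a step that the limit leaves unreadable from compound 2 to compound 3, cannot be sized. Taken together, all three compounds show an effect only at large amounts of compound.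

Compound 4 `COC(=O)c1ccc(NCc2cncn2Cc2ccc(-c3ccccc3)cc2)cc1-c1ccccc1` has not yet been measured. It differs from compound 1 by methoxy in place of methyl on a carbonyl carbon. Within the data shown here, no measured pair carries this same change, so its size cannot be read from the data. Compound 2 and compound 3, which already carry the methoxycarbonyl group, sit at high values, as does compound 1, so the step is expected to be no larger than the scatter, a number no higher from compound 1 to compound 4 (the limit leaves the size open). Compound 4 is therefore estimated at 10000 nM, with a range from 3000 nM to 30000 nM, and a fair chance that only a limit is reported.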

Compound 4, half-maximal effective concentration: > 1000 nM
Compound 4: no number, only a limit; the forecaster's own chance of this, stated with the estimate: 65%; the middle value lies beyond the limit too.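

The steps linking compound 4 with compound 1, compound 2 and compound 3 cannot be read, as each involves a limit of the assay and not a number. Still open, as far as these compounds go, is whether methoxy in place of methyl on a carbonyl carbon shifts the read-out at all.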